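This account rests on a few compounds, and the source may have more. Where it says the series, first, only, none or still open, it means among the compounds named here.

Measured so far in a functional assay on cells for agonist activity at Free fatty acid receptor 1 (Mus musculus), read by FLIPR and calcium flux, with a stated time of 5 min; on this read-out higher numbers stand for an effect only at larger amounts of compound and lower numbers for an effect already at smaller amounts:
compound 1, `Cc1nn(-c2ccccn2)c2cc(-c3ccc(CCC(=O)O)cc3)ccc12`: 1400 nM
compound 2, `Cc1nn(-c2ccccn2)c2cc(-c3ccc(CCC(=O)O)cc3F)ccc12`: 1500 nM

Compound 2 and compound 1 lie within the scatter of each other, so neither can be called the more potent of the two. Among the measured compounds shown here, the single change between them, fluoro in place of hydrogen on an aromatic carbon, gave a 1.1-fold higher number from compound 1 to compound 2 (0.03 log units; within the scatter).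

Compound 3 `Cc1nn(-c2ccccn2)c2cc(-c3ccc(CCC(=O)O)cc3Cl)ccc12` is not yet measured. It differs from compound 2 by chloro in place of fluoro on an aromatic carbon. For the measured compounds named here, the only measured step that bears on this is the one from compound 1 to compound 2, where a halogen first entered at this very position and the number stayed within the scatter. Swapping that fluoro for chloro is therefore expected to leave the number close to where compound 2 stands, with a 1.2-fold lower number from compound 2 to compound 3 (0.06 log units; within the scatter). For compound 3 the estimate in this assay is 1300 nM, with a range from 600 nM to 3000 nM.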

Compound 3, half-maximal effective concentration in the Free fatty acid receptor 1 assay: 1200 nM
Estimate against measurement, compound 3: 1.1-fold (0.03 log units) above; the range from low to high includes it.
By their numbers in the Free fatty acid receptor 1 assay, from the lowest: compounds 3, 1 and 2 (each within the scatter of the next).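

At the aromatic carbon ortho to a large group and meta to a 2-carboxyethyl group, hydrogen, fluoro and chloro now give no readable difference in the Free fatty acid receptor 1 assay: there is a 1.2-fold lower number from compound 1 to compound 3 (0.07 log units; within the scatter), and a 1.3-fold lower number from compound 2 to compound 3 (0.10 log units; within the scatter). This carbon therefore takes chloro as well as fluoro without a shift that can be told from the scatter. The swap does register in a physicochemical assay for lipophilicity, using the shake flask method, measured as octanol-water partition, with a stated time of 30 min, at pH 7.4 (on this read-out higher numbers stand for higher lipophilicity and lower numbers for lower lipophilicity), where compound 2 gives 2.9 and compound 3 gives 3.3, so lipophilicity differs between the two halogen compounds while the number for the receptor does not: the measured distribution coefficient of compound 2, 2.9, and of compound 3, 3.3, a number 0.40 log units higher (beyond the scatter)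

From the compounds shown here alone, all three compounds carry only hydrogen or a halogen at this carbon, so what a methoxy group, a nitrile or an amine would do there remains open. Also open, going by these compounds, is whether any group at this carbon can move the number in the Free fatty acid receptor 1 assay beyond the scatter.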